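The source may hold more compounds than are shown below. What is called first, only, known or untested is meant among the compounds shown, and "the series" means these compounds.

Measured compounds:
- compound 1 `COc1ccc(CSc2nnc(-c3cc(OC)c(OC)c(OC)c3)n2-c2ccc(OC)cc2)cc1`: in a functional assay on HCT-116 cells (Homo sapiens) for inhibition, read by MTT assay, with a stated time of 48 h (a higher number here means a weaker inhibitor, a lower number a stronger inhibitor), compound 1 gives 49600 nM
- compound 2 `COc1ccc(CSc2nnc(-c3cc(OC)c(OC)c(OC)c3)n2-c2ccc(N(C)C)cc2)cc1`: in this assay compound 2 gives 1150 nM

Of the two numbers shown, compound 2 has the lower one; the single step between them, a 43-fold lower number from compound 1 to compound 2 (1.63 log units; beyond the scatter), is large and lies beyond the scatter, and it concerns a swap on the aromatic ring attached to the core.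

Compound 3 `CCOC(=O)CSc1nnc(-c2cc(OC)c(OC)c(OC)c2)n1-c1ccc(N(C)C)cc1` keeps that dimethylamino-bearing ring and instead alters the chain on the sulfur: ethoxycarbonyl in place of 4-methoxyphenyl on a saturated chain carbon bound to a sulfur. No measured step touches this part of the structure, so the one step shown gives no guidance on direction or size for this change. With nothing to lean on, the expected step of a 1.7-fold higher number from compound 2 to compound 3 (0.24 log units; within the scatter) is set close to no change, with a wide band to allow for either outcome. Compound 3 is therefore estimated at 2000 nM in this assay, within a range from 300 nM to 12000 nM.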

Compound 3, half-maximal inhibitory concentration: > 60000 nM
Compound 3: no number, only a limit (the forecaster's own chance of this, stated with the estimate: 10%); middle value at least 30-fold (1.47 log units) away from the limit.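

In this assay, putting ethoxycarbonyl in place of 4-methoxyphenyl on the saturated chain carbon bound to a sulfur gives an at least 52-fold higher number from compound 2 to compound 3 (1.71 log units; beyond the scatter), so this part of the structure, untouched by the earlier step, also strongly affects the read-out. The entry for compound 3 is a limit of the assay and not a number, so the step has a lower bound but no exact size: the limit of > 60000 nM in this assay, at which 1 of the 3 values shown sits. The dimethylamino group present in compound 2 is also present in compound 3, so that group alone does not secure a low number.

With a single replacement at this position, the change cannot be assigned to losing the 4-methoxyphenyl or to gaining the ethoxycarbonyl. An unsubstituted benzyl, a simple ethyl chain or a carboxylic acid on the sulfur chain would help to separate these two readings.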